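A few compounds are considered here, and "the series" means these few. Any claim that something is new, unique, unknown or untested is made for them only; others in the source may bear on it.

Measured so far:
compound 1, `Cc1cc(C(N)=O)nn1Cc1cc(Cl)ccc1OCc1ccccc1`: 126 nM
compound 2, `CC(=O)Nc1cc(C)n(Cc2cc(Cl)ccc2OCc2ccccc2)n1`: 316 nM

Both values come from an assay on CHO-K1 cells for displacement of a labelled ligand from prostaglandin E2 receptor EP1 subtype (Homo sapiens); a higher number here means a weaker inhibitor, a lower number a stronger inhibitor. For the measured compounds named here, compound 2 has the higher number of the two; the only measured step, a 2.5-fold higher number from compound 1 to compound 2 (0.40 log units; beyond the scatter), separates it from compound 1, its nearest neighbour. Compound 3, `Cc1cc(NC(=O)C2CCCO2)nn1Cc1cc(Cl)ccc1OCc1ccccc1`, has not yet been measured. It differs from compound 2 in one place: oxolan-2-yl in place of methyl on a carbonyl carbon. Going by the values given here, no measured step covers a change at this carbonyl carbon. Among the compounds with values here, the single step available, a 2.5-fold higher number from compound 1 to compound 2 (0.40 log units; beyond the scatter), concerns the group on the aromatic carbon and shows that altering that part of the molecule moves the number only modestly; it says nothing about enlarging the acyl group. With nothing closer to lean on, the expectation for compound 3 is a shift not clearly beyond the scatter in either direction, written as a 1.3-fold lower number from compound 2 to compound 3 (0.10 log units; within the scatter). The estimate for compound 3 is 250 nM, with a range from 80 nM to 800 nM that reflects the absence of a matching step.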

Compound 3, half-maximal inhibitory concentration: 39.8 nM
The estimate for compound 3 lay 6.3-fold (0.80 log units) above the measured number; the measured number lies below the stated range.
By their numbers in this assay, from the lowest: compound 3; then compound 1; then compound 2.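

In this assay, for the compounds shown here, the group carried on the carbonyl carbon of the amide proves to be a responsive position: oxolan-2-yl in place of methyl gives a 7.9-fold lower number from compound 2 to compound 3 (0.90 log units; beyond the scatter) and runs opposite to the only earlier step (a 2.5-fold higher number from compound 1 to compound 2 (0.40 log units; beyond the scatter)). The loss seen on going from carbamoyl to acetamido is therefore not general to acylated amino groups on this aromatic carbon, since ((oxolan-2-yl)carbonyl)amino in place of carbamoyl gives a 3.2-fold lower number from compound 1 to compound 3 (0.50 log units; beyond the scatter) and compound 2 alone among the acylated pair sits above compound 1. Nothing available accounts for the gain from the entering ring.

With only methyl and oxolan-2-yl on this carbonyl carbon, the series cannot separate the contribution of the ring oxygen from that of the ring carbons or of the larger group as a whole. A cyclopentyl group would test the ring without its oxygen, a methoxyethyl chain would test the oxygen without the ring, and oxolan-3-yl would test where the ring is attached to the carbonyl carbon.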